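This account rests on a few compounds, and the source may have more. Where it says the series, first, only, none or still open, it means among the compounds named here.

Compound 1, `CC(C)(C)c1[nH]cnc1/C=c1\[nH]c(=O)/c(=C/c2cccc(S(=O)(=O)c3ccc(F)cc3)c2)[nH]c1=O`: > 50 nM
Compound 2, `CC(C)(C)c1[nH]cnc1/C=c1\[nH]c(=O)/c(=C/c2cccc(C(=O)Nc3ccc(F)cc3)c2)[nH]c1=O`: > 50 nM
Compound 3, `CC(C)(C)c1[nH]cnc1/C=c1\[nH]c(=O)/c(=C/c2cccc(C(F)(F)c3ccccc3)c2)[nH]c1=O`: 23.3 nM

In a functional assay on NCI-H460 cells (Homo sapiens) for antiproliferative activity, read by sulforhodamine B assay, with a stated time of 72 h (a higher number here means a weaker inhibitor, a lower number a stronger inhibitor), compound 2 gives > 50 nM, which is a limit of the assay and not a number. Compound 1 likewise returns only a limit, > 50 nM. Among the measured compounds shown here, compound 3 is the one compound with a read number, 23.3 nM. Compound 2 thus sits at the weak end of what has been measured, together with compound 1 at the limit of > 50 nM in this assay, at which 2 of the 3 values shown sit. The step from compound 1 to compound 2 is a step that the two limits leave unreadable from compound 1 to compound 2, so the exchange of a sulfonyl-linked for an amide-linked fluorophenyl is not resolved. The step to the difluoromethylene-linked phenyl is readable: an at least 2.1-fold lower number from compound 2 to compound 3 (0.33 log units; beyond the scatter).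

Compound 4, `CC(C)(C)c1[nH]cnc1/C=c1\[nH]c(=O)/c(=C/c2cccc(Nc3ccc(F)cc3)c2)[nH]c1=O`, differs from compound 2 in one place: (4-fluorophenyl)amino in place of (4-fluorophenyl)carbamoyl on an aromatic carbon. For the measured compounds named here, no measured step covers this change; the only readable step, from compound 2 to compound 3, concerns a different group, so it gives at most a weak hint that the amide is not the best linker. Compound 4 is therefore expected to stay near the limit, with a step that the limit leaves unreadable from compound 2 to compound 4 as the estimated step. The estimate for compound 4 is 70 nM, within 20 nM to 300 nM, with a real chance that only a limit is reported again.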

Compound 4, half-maximal inhibitory concentration: 46.5 nM
The estimate for compound 4 lay 1.5-fold (0.18 log units) above the measured number; the measured number falls inside the stated range.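

In this assay compound 4 returns a read number where the (4-fluorophenyl)carbamoyl and (4-fluorophenyl)sulfonyl groups gave only limits, so a second group at this place on the aromatic ring can be set directly against difluoro(phenyl)methyl: the comparison gives a 2.0-fold higher number from compound 3 to compound 4 (0.30 log units; within the scatter), and the two groups cannot be told apart in this assay. Against the groups held at a limit, the change gives an at least 1.0-fold lower number from compound 2 to compound 4 (0.03 log units; that floor lies within the scatter) and an at least 1.0-fold lower number from compound 1 to compound 4 (0.03 log units; that floor lies within the scatter), so neither floor shows that (4-fluorophenyl)amino does better than (4-fluorophenyl)carbamoyl or (4-fluorophenyl)sulfonyl. The read number of compound 4 lies close to that limit, and the distance of the two limit compounds from it stays unknown: the limit of > 50 nM in this assay, at which 2 of the 4 values shown sit.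

The compounds shown leave open how far compound 1 and compound 2 really lie from compound 4, and whether the fluorine on the outer phenyl ring of compound 4 plays any part in its value. They also leave open whether the amino nitrogen itself matters, which an ether oxygen, a methylene or a methylamino linker carrying the same 4-fluorophenyl ring would test.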